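A few compounds are considered here, and "the series" means these few. Any claim that something is new, unique, unknown or untested is made for them only; others in the source may bear on it.

Compound 2 `Cc1ccccc1-c1nnc(NNC2CCCC2)s1` and compound 1 `Cc1ccccc1-c1nnc(NNC(C)C)s1` share one core and differ only in the group on the amine nitrogen. In a functional assay on the whole organism with Mus musculus as the target, in the maximal electroshock model, with a stated time of 1 h (on this read-out higher numbers stand for an effect only at larger amounts of compound and lower numbers for an effect already at smaller amounts), compound 1 gives 83 mg/kg. In this assay compound 2 gives > 100 mg/kg, which is a limit of the assay and not a number. Among the compounds with values here, the single measured step, an at least 1.2-fold higher number from compound 1 to compound 2 (0.08 log units; that floor lies within the scatter), is therefore known only as a floor, set by the limit of > 100 mg/kg in this assay, at which 1 of the 2 values shown sits.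

Compound 3 `Cc1ccccc1-c1nnc(N(C)NC2CCCC2)s1` differs from compound 2 in one place: methyl in place of hydrogen on a nitrogen on an aromatic ring. Within the data shown here, no measured step touches this nitrogen; the one step on record concerns the amine nitrogen, and it is itself truncated at the limit. The data thus give no ground for expecting a step beyond the scatter in this assay in either direction, and since compound 2 already sits at the limit, compound 3 is expected to land near or past it too.

Compound 3 is accordingly expected to give about 130 mg/kg in this assay. The range expected for compound 3 runs from 60 mg/kg to 280 mg/kg. For compound 3 this estimate amounts to an expected step that the limit leaves unreadable from compound 2 to compound 3.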

Compound 3, dose for half-maximal effect: 110 mg/kg
Compound 3: middle estimate off by 1.2-fold (0.07 log units), on the high side, and the stated range covers the measured number.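

Within the data shown here, no step from compound 2 to compound 3 can be read in this assay, since the value of compound 2 is a limit of the assay and not a number: the limit of > 100 mg/kg in this assay, at which 1 of the 3 values shown sits. The compounds shown leave open whether methyl in place of hydrogen on a nitrogen on an aromatic ring shifts the read-out at all, and in which direction.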